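The source may hold more compounds than are shown below. What is called first, only, known or untested is meant among the compounds shown, and "the series" means these compounds.

Working notes on the series. Compound 1 `CC1COC2(CCN(c3nc(=O)c4cc(C(F)(F)F)cc([N+](=O)[O-])c4s3)CC2)O1` and compound 2 `CCCCC(=O)N1CCN(c2nc(=O)c3cc(C(F)(F)F)cc([N+](=O)[O-])c3s2)CC1` have both been run in an ADME assay on Vero cells (Chlorocebus sabaeus) for cytotoxicity, read by MTT assay, with a stated time of 72 h; on this read-out lower numbers stand for higher toxicity in this test and higher numbers for lower toxicity in this test. For compound 1 the result in this assay is a limit of the assay, > 125000 nM. For compound 2 the result in this assay is likewise a limit of the assay, > 125000 nM. Compound 2 therefore stands at the limit of > 125000 nM in this assay, at which 2 of the 2 values shown sit, with no number of its own. Compound 3 `CC(C)CC(=O)N1CCN(c2nc(=O)c3cc(C(F)(F)F)cc([N+](=O)[O-])c3s2)CC1` awaits measurement in this assay; it differs from compound 2 by isopropyl in place of propyl on a saturated chain carbon bound to a carbonyl carbon. For the measured compounds named here, no measured step rests on such a change, so the step that the limit leaves unreadable from compound 2 to compound 3 is expected to stay within the scatter. Compound 3 is expected at 150000 nM, within 100000 nM to 300000 nM, most likely again as a limit only.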

Compound 3, half-maximal cytotoxic concentration: > 125000 nM
Compound 3: a limit, no number (the forecaster's own chance of this, stated with the estimate: 85%); the middle value lies beyond the limit too.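

The results for compound 2 and compound 3 in this assay are both limits, so no step can be read between them: the limit of > 125000 nM in this assay, at which 3 of the 3 values shown sit.

The compounds shown leave open whether isopropyl in place of propyl changes anything in this assay, since none of the three has a number of its own.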